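Shrinking the Ring Substituent on a PLK1 Inhibitor Core

The source may report more compounds than this note shows. Statements on the series, on what has been measured and on what is new or still open speak of the compounds shown alone.

Compound 1, `COc1cc(C(=O)NC2CCN(C)CC2)ccc1Nc1ncc2c(n1)N(C1CCCC1)[C@H](C)C(=O)N2C`: 1.1 nM
Compound 2, `COc1cc(C(=O)NC2CCN(C)CC2)ccc1Nc1ncc2c(n1)N(C1CCCCC1)[C@H](C)C(=O)N2C`: 8.6 nM

Both compounds were tested in an assay on isolated protein for inhibition of serine/threonine-protein kinase PLK1 (Homo sapiens), read by Z'-LYTE; a lower number here means a stronger inhibitor, a higher number a weaker inhibitor. Among the measured compounds shown here, of the two numbers, compound 2 holds the higher one, and the single step of a 7.8-fold higher number from compound 1 to compound 2 (0.89 log units; beyond the scatter) lies beyond the scatter, so compound 1 is the stronger inhibitor of the pair.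

Compound 3, `COc1cc(C(=O)NC2CCN(C)CC2)ccc1Nc1ncc2c(n1)N(C(C)C)[C@H](C)C(=O)N2C`, has not yet been measured. Its change from compound 2 is isopropyl in place of cyclohexyl on a nitrogen on an aromatic ring in a ring. For the measured compounds named here, only one measured step bears on this position, a 7.8-fold higher number from compound 1 to compound 2 (0.89 log units; beyond the scatter), in which the six-membered ring in place of the five-membered one gave the higher number. The new group has no ring at all and fewer heavy atoms, so that step is only a loose guide; the direction it points is toward a lower number, with real uncertainty about size. The expected step is a 2.9-fold lower number from compound 2 to compound 3 (0.46 log units; beyond the scatter). Compound 3 is therefore estimated at 3 nM, within a range of 0.8 nM to 12 nM.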

Compound 3, half-maximal inhibitory concentration: 25.2 nM
Estimate against measurement, compound 3: 8.4-fold (0.92 log units) below; measured number above the stated range.
By their numbers in this assay, from the lowest: compound 1; then compound 2; then compound 3.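

In this assay, taking away the ring and shrinking the group does not restore strength: isopropyl in place of cyclohexyl gives a 2.9-fold higher number from compound 2 to compound 3 (0.47 log units; beyond the scatter) and so moves the number up, not down. Set against cyclopentyl, the same change gives a 23-fold higher number from compound 1 to compound 3 (1.36 log units; beyond the scatter) and is the largest step seen at this position. The number therefore rises on going from cyclopentyl either to the larger cyclohexyl or to the ring-free isopropyl, but nothing available here explains this order.

Still open, as far as these compounds go, is where a cyclobutyl ring or a straight propyl chain would fall, and whether a tetrahydropyranyl ring, with an oxygen atom in it, would fit the same order. From the compounds shown here alone, all three compounds also keep the methyl group on the ring atom next to this nitrogen, so it remains unknown whether the order would hold with a hydrogen atom or an ethyl group there.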